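Swapping tert-butyl for fluoro on the most active compound

The source may hold more compounds than are shown below. What is called first, only, known or untested is meant among the compounds shown, and "the series" means these compounds.

Measured in a functional assay on A549 cells (Homo sapiens) for antiproliferative activity, read by MTT assay, with a stated time of 72 h; a higher number here means a weaker inhibitor, a lower number a stronger inhibitor:
Compound 1 `CC(C)(C)c1ccc(SC(=S)N2CCCCC2)cc1`: 9130 nM
Compound 2 `CCCCN(CCCC)C(=S)Sc1ccccc1`: 9760 nM
Compound 3 `CC(C)(C)OC(=O)N1CCN(C(=S)Sc2ccc(C(C)(C)C)cc2)CC1`: 769 nM

Of the compounds shown here, three have been measured so far. Compound 1 and compound 2 lie within the usual scatter of each other. Compound 3 stands apart at 769 nM, the lowest of the three numbers, and its gaps to both of the others lie beyond the scatter. It is therefore the strongest inhibitor of the set.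

Compound 4 `CC(C)(C)OC(=O)N1CCN(C(=S)Sc2ccc(F)cc2)CC1` departs from compound 3 in one place: fluoro in place of tert-butyl on an aromatic carbon. This puts fluoro in place of tert-butyl on an aromatic carbon, para to a large group. For the measured compounds named here, no measured pair isolates this change, and no measured compound carries fluoro, so the data offer only indirect guidance. Compound 3, at 769 nM, sits well below the other two, so a further gain seems less likely than some loss. In this assay the expected change is a moderate move towards weaker inhibition, estimated as a 2.3-fold higher number from compound 3 to compound 4 (0.37 log units; beyond the scatter). For compound 4 the estimated value is 1800 nM, with an expected range from 500 nM to 6500 nM.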

Compound 4, half-maximal inhibitory concentration: 1560 nM
Estimate against measurement, compound 4: 1.2-fold (0.06 log units) above; measured number inside the range.
By their numbers in this assay, from the lowest: compound 3; then compound 4; then compounds 1 and 2 (each within the scatter of the next).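

In this assay, for the compounds shown here, this is the first pair to isolate the position, and it gives a 2.0-fold higher number from compound 3 to compound 4 (0.31 log units; beyond the scatter). Replacing tert-butyl on the aromatic carbon, para to a large group, with fluoro exchanges four carbon atoms for a single fluorine atom, and the loss in activity is modest but beyond the scatter, so the choice of group at this position matters without being decisive for activity in this pair. No available measurement bears on why the number moves, whether through the difference in size or in some other way.

With only tert-butyl and fluoro compared at this position, the compounds shown leave open how a chlorine atom, a methoxy group or a plain hydrogen would behave there, and therefore whether the values follow the size of the group at all. They also leave open whether the same swap would carry a similar cost in a compound that has an amine or a carboxylic acid elsewhere on the shared core.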